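Shifting the Chlorine on the Chlorophenyl Group

A few compounds are considered here, and "the series" means these few. Any claim that something is new, unique, unknown or untested is made for them only; others in the source may bear on it.

Of the compounds shown here, three built on one shared core have been measured in a functional assay on cells (T-cell, Mus musculus, strain BALB/c) for inhibition, read by MTT assay, with stated times of 24 h and 72 h; a higher number here means a weaker inhibitor, a lower number a stronger inhibitor. Compound 1 `COc1cc(-c2nnc(SCc3ccc([N+](=O)[O-])cc3)o2)ccc1O` gives 14200 nM. Compound 2 `COc1cc(-c2nnc(SCc3cccc([N+](=O)[O-])c3)o2)ccc1O`, which also bears a nitro group, gives 16000 nM; the two values lie close together. Compound 3 `COc1cc(-c2nnc(SCc3ccc(Cl)cc3)o2)ccc1O` gives 11100 nM, the lowest of the three numbers, though its distance to compound 1 and to compound 2 falls within the usual scatter, so no ordering among them can be claimed. Going by the values given here, the only single-point step known among them, a 1.3-fold lower number from compound 1 to compound 3 (0.11 log units; within the scatter), is likewise within the scatter.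

Compound 4 `COc1cc(-c2nnc(SCc3ccccc3Cl)o2)ccc1O` has not yet been measured. It differs from compound 3 only in 2-chlorophenyl in place of 4-chlorophenyl on a saturated chain carbon bound to a sulfur. Among the compounds with values here, no measured step moves a chlorine from one place on the ring to another; the closest comparison is the pair of compound 1 and compound 2, whose values differ by little. Since the step of a 1.3-fold lower number from compound 1 to compound 3 (0.11 log units; within the scatter) also altered nothing beyond the scatter, a positional shift of the chlorine is not expected to do more. The step of a 1.1-fold higher number from compound 3 to compound 4 (0.03 log units; within the scatter) is therefore expected to amount to no change beyond the scatter. The estimate for compound 4 in this assay is 12000 nM, ranging from 6000 nM to 25000 nM.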

Compound 4, half-maximal inhibitory concentration: 8430 nM
The estimate for compound 4 lay 1.4-fold (0.15 log units) above the measured number, and the stated range covers the measured number.
By their numbers in this assay, from the lowest: compounds 4, 3, 1 and 2 (each within the scatter of the next).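

Going by these compounds alone, compound 4 gives the first measured step in which only the place of the chlorine changes, with 2-chlorophenyl in place of 4-chlorophenyl on a saturated chain carbon bound to a sulfur. In this assay, that step is a 1.3-fold lower number from compound 3 to compound 4 (0.12 log units; within the scatter), so the two chlorine placements cannot be told apart, whereas the earlier step from compound 1 to compound 3 had exchanged one group for another and had not tested a shift of the same group. No measurement is available that could explain this result or show what, if anything, the place of the chlorine contributes.

The compounds shown carry only chloro and nitro on the aromatic ring, and since each value in this assay lies within the scatter of the next, they do not establish any ordering or show which changes at this ring could move the number beyond the scatter. From the compounds shown here alone, it remains open whether an amine or a carboxylic acid on that ring, or a longer chain in place of the single saturated carbon bound to the sulfur, would produce such a step.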